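The source may report more compounds than this note shows. Statements on the series, on what has been measured and on what is new or still open speak of the compounds shown alone.

Compound 1 `CC(O)(COc1cccc(C(F)(F)F)c1)C(=O)Nc1ccc(S(F)(F)(F)(F)F)cc1` and compound 2 `CC(O)(COc1cc(C(F)(F)F)cc(C(F)(F)F)c1)C(=O)Nc1ccc(S(F)(F)(F)(F)F)cc1` share a core, and compound 2 carries one extra group; the two differ as follows: trifluoromethyl in place of hydrogen on an aromatic carbon. In a functional assay on CWR22R cells (Homo sapiens) for antiproliferative activity, read by propidium iodide staining, with a stated time of 96 h (a lower number here means a stronger inhibitor, a higher number a weaker inhibitor), compound 1 gives 14600 nM, and in this assay compound 2 gives 7000 nM. That change produced a 2.1-fold lower number from compound 1 to compound 2 (0.32 log units; beyond the scatter).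

Compound 3 `CC(O)(CS(=O)(=O)c1cccc(C(F)(F)F)c1)C(=O)Nc1cccc(S(F)(F)(F)(F)F)c1` is built on a different core; how the core of compound 3 differs from the core of compound 1 is not broken down here. In this assay compound 3 gives 24600 nM, which stands within the scatter of the value of compound 1 and is a higher number than the value of compound 2.

Compound 4 `CC(O)(CS(=O)(=O)c1cc(C(F)(F)F)cc(C(F)(F)F)c1)C(=O)Nc1cccc(S(F)(F)(F)(F)F)c1` is not yet measured. It differs from compound 3 in the same way that compound 2 differs from compound 1: trifluoromethyl in place of hydrogen on an aromatic carbon. The place of the change is described in the same words in both pairs, so this is the same change, carried onto another core.

For the measured compounds named here, the expectation rests on one earlier example, because the step of a 2.1-fold lower number from compound 1 to compound 2 (0.32 log units; beyond the scatter) is the only measurement of this change that is available here, and it is modest. The same change on the core of compound 3 is estimated to give a step of a 2.1-fold lower number from compound 3 to compound 4 (0.31 log units; beyond the scatter), with the caution that a single prior example is a thin base. Compound 4 is therefore expected to reach about 12000 nM in this assay, most likely between 6000 nM and 25000 nM.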

Compound 4, half-maximal inhibitory concentration: 9300 nM
Beside the measured number, compound 4's estimate is 1.3-fold (0.11 log units) above it, and the stated range covers the measured number.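

On the second core, trifluoromethyl in place of hydrogen on an aromatic carbon gave a 2.6-fold lower number from compound 3 to compound 4 (0.42 log units; beyond the scatter) in this assay, so the number falls on this core as it did on the first. Set side by side, the two steps do not differ in size: the same change on two cores in this assay, a 2.1-fold lower number (0.32 log units; beyond the scatter) from compound 1 to compound 2 and a 2.6-fold lower number (0.42 log units; beyond the scatter) from compound 3 to compound 4, 1.3-fold (0.10 log units) apart, within the scatter of two such steps This shows that, in these two pairs, the change carried from one core to the other with a modest step of similar size in the same direction, but two pairs are a small base and do not show that it would do the same on every core in the series, nor do they explain why the number falls.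

The compounds shown carry only trifluoromethyl as the added group at this place, so it remains open whether a chlorine atom, a nitrile or a methyl group in place of that hydrogen would give a step of similar size. From the compounds shown here alone, it also remains open whether the same step would appear on a third core, and whether it would hold in any measurement other than this assay.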